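Loss of a tert-Butoxycarbonyl Group in Weak Cell Inhibitors

The compounds below may be only part of what the source reports. "The series", "measured", "known", "first", "only" and "open" are said of these compounds alone.

Of the compounds shown here, three have been tested in a functional assay on ECa-109 cells (Homo sapiens) for inhibition, read by MTT assay, with a stated time of 72 h; a higher number here means a weaker inhibitor, a lower number a stronger inhibitor. Compound 1 `CC(C)(C)OC(=O)N1CCN(C(=S)SCc2cn(Cc3ccc(Cl)cc3)nn2)CC1` gives only a limit in this assay, > 128000 nM. Compound 2 `COc1cc(Cn2cc(CSC(=S)N3CCNCC3)nn2)cc(OC)c1OC` likewise gives only a limit, > 128000 nM. Among the compounds with values here, compound 3 `COc1cc(Cn2cc(CSC(=S)N3CCN(C(=O)OC(C)(C)C)CC3)nn2)cc(OC)c1OC`, the one compound with a measured number, gives 44400 nM in this assay. Compound 2 arises from compound 3 by a single change, (hydrogen in place of tert-butoxycarbonyl on an amine nitrogen in a ring), and that step, an at least 2.8-fold higher number from compound 3 to compound 2 (0.45 log units; beyond the scatter), weakens the inhibitor. How the core of compound 1 differs from that of compound 3 is not broken down here. Compound 4 `S=C(SCc1cn(Cc2ccc(Cl)cc2)nn1)N1CCNCC1` has not been measured; it arises from compound 1 by the same change, (hydrogen in place of tert-butoxycarbonyl on an amine nitrogen in a ring). Since compound 1 already sits at the limit of > 128000 nM in this assay, at which 2 of the 3 values shown sit, no number inside the measured range is expected for compound 4. The step that the limit leaves unreadable from compound 1 to compound 4 is expected to be small or at most modest, and this rests on the weakening that the same change gave in an at least 2.8-fold higher number from compound 3 to compound 2 (0.45 log units; beyond the scatter). The estimate for compound 4 in this assay is 200000 nM, most likely reported only as a limit, within a range from 128000 nM to 600000 nM.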

Compound 4, half-maximal inhibitory concentration: > 128000 nM
Compound 4: no number, only a limit (the forecaster's own chance of this, stated with the estimate: 90%); the middle value does not contradict the limit.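

Compound 1 and compound 4 each give only a limit in this assay, not a number, so the step between them cannot be read: the limit of > 128000 nM in this assay, at which 3 of the 4 values shown sit.

The compounds shown leave open whether hydrogen in place of tert-butoxycarbonyl changes the inhibition on the core of compound 1, as it did on the core of compound 3.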